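Dropping a Methyl Group From Compound 2

This account rests on a few compounds, and the source may have more. Where it says the series, first, only, none or still open, it means among the compounds named here.

Compound 1 `CCCc1nc(Br)c2c(Br)nnc(O)n12` gives 48000 nM in a functional assay for inhibition, with Homo sapiens as the target; a higher number here means a weaker inhibitor, a lower number a stronger inhibitor.
Compound 2 `Cc1nnc(S)n2c(C)nc(C)c12` reaches only the limit of this assay, > 48000 nM.
Compound 3 `COCc1ncc2cnnc(S)n12` likewise stops at the limit of this assay, > 48000 nM.

Compound 2 therefore stands at the weak end of what this assay can report, and it shares that position with compound 3: the limit of > 48000 nM in this assay, at which 2 of the 3 values shown sit. Only compound 1 returns an actual number, and that number lies at the same concentration as the limit.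

Compound 4 `Cc1nc(C)n2c(S)nncc12` is the next step from compound 2. The change is small: hydrogen in place of methyl on an aromatic carbon. For the measured compounds named here, no pair of measured compounds differs in one place, so no measured step exists to compare with. With compound 2 already at the limit, the step in this assay is expected to be none beyond the scatter, or a slight weakening. Compound 4 is estimated at 70000 nM, within 20000 nM to 300000 nM, and the estimated step that the limit leaves unreadable from compound 2 to compound 4 is expected to be small.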

Compound 4, half-maximal inhibitory concentration: > 48000 nM
Compound 4 ended at the assay's limit; the forecaster's own chance of this, stated with the estimate: 75%; the middle value is on the limit's open side.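

No step can be read between compound 2 and compound 4 because both stop at a limit: the limit of > 48000 nM in this assay, at which 3 of the 4 values shown sit. The compounds shown leave open whether hydrogen in place of methyl on an aromatic carbon changes inhibition in this assay at all.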